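Uracil-type series with benzyloxymethyl-bearing side chain: antiproliferative notes

This account rests on a few compounds, and the source may have more. Where it says the series, first, only, none or still open, it means among the compounds named here.

Measured compounds:
compound 1 `O=c1cc(CC(COCc2ccccc2)COCc2ccccc2)[nH]c(=O)[nH]1`, > 100000 nM
compound 2 `COCn1c(CC(COCc2ccccc2)COCc2ccccc2)cc(=O)[nH]c1=O`, > 100000 nM
compound 3 `COCn1c(=O)[nH]c(CC(COCc2ccccc2)COCc2ccccc2)c(C)c1=O`, 27300 nM

All three were run in a functional assay on MIA PaCa-2 cells (Homo sapiens) for antiproliferative activity, read by MTT assay, with a stated time of 72 h; on this read-out higher numbers stand for weaker inhibition and lower numbers for stronger inhibition. For compound 1 the value > 100000 nM is a limit of the assay, not a number. For compound 2 the value > 100000 nM is likewise a limit. Going by the values given here, compound 3 gives 27300 nM in this assay, the only number among the three. As stated by the limit of > 100000 nM in this assay, at which 2 of the 3 values shown sit, the values of compound 1 and compound 2 sit at that limit.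

The change from compound 1 to compound 2 is methoxymethyl in place of hydrogen on an aromatic nitrogen. Its step in this assay, a step that the two limits leave unreadable from compound 1 to compound 2, cannot be read because both values are limits. The difference between the cores of compound 1 and compound 3 is not broken down here.

Compound 4 `COCn1c(CC(COCc2ccccc2)COCc2ccccc2)c(C)c(=O)n(COC)c1=O` has not been measured. It differs from compound 3 by methoxymethyl in place of hydrogen on an aromatic nitrogen, the same kind of change as from compound 1 to compound 2; around the place, compound 4 has the new group meta to a methoxymethyl group and meta to a methyl group, which the earlier change does not. Since the earlier step is unreadable, the expected step of a 1.5-fold higher number from compound 3 to compound 4 (0.17 log units; within the scatter) rests only on the value of compound 3, 27300 nM, and is taken as small. Compound 4 is therefore estimated at 40000 nM in this assay, with a range from 10000 nM to 150000 nM.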

Compound 4, half-maximal inhibitory concentration: 500 nM
For compound 4 the middle estimate is 80-fold (1.90 log units) above the measured one; the measured number lies below the stated range.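

In this assay, methoxymethyl in place of hydrogen on an aromatic nitrogen gives a 55-fold lower number from compound 3 to compound 4 (1.74 log units; beyond the scatter), so on the core of compound 3 this single change carries a large gain, with compound 4 at 500 nM. Compound 1 and compound 2 both stand at a limit of the assay, not at a number, so the same change on their core cannot be read and neither supports nor contradicts the new step: the limit of > 100000 nM in this assay, at which 2 of the 4 values shown sit. The change therefore has one readable instance in this series, which does not show that it carries from one core to another, nor whether the large step depends on the new group being meta to a methoxymethyl group and meta to a methyl group, as it is in compound 4.

Still open, as far as these compounds go, is whether methoxymethyl itself is required on that aromatic nitrogen, or whether a plain ethyl group, a longer ether chain or a chain ending in an amine would read the same way in this assay. Also open, from the compounds shown here alone, is how the core of compound 4 reads without its methyl group, a pair that would separate that group's part in the result from that of the added methoxymethyl.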